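This account rests on a few compounds, and the source may have more. Where it says the series, first, only, none or still open, it means among the compounds named here.

Values in a physicochemical assay for lipophilicity, using the shake flask method, at pH 7.4; on this read-out lower numbers stand for lower lipophilicity and higher numbers for higher lipophilicity:
- compound 1 `CCCC(Oc1ccc(-n2cc(OC)cn2)cc1)c1ccc(C(=O)NCCC(=O)O)cc1`: 1.4
- compound 2 `CCCC(Oc1ccc(-n2cc3c(n2)CCCC3)cc1)c1ccc(C(=O)NCCC(=O)O)cc1`: 2.7
- compound 3 `CCCC(Oc1ccc(-n2cc(F)cn2)cc1)c1ccc(C(=O)NCCC(=O)O)cc1`: 2

Compound 3, at 2, is second highest of the three, above compound 1 and under compound 2. Next comes compound 4 `CCCC(Oc1ccc(-n2cc(C)cn2)cc1)c1ccc(C(=O)NCCC(=O)O)cc1`: methyl in place of fluoro on an aromatic carbon. Among the compounds with values here, two measured steps bear on this. With fluoro in place of methoxy, the change was modest: a number 0.60 log units higher from compound 1 to compound 3 (beyond the scatter). The other modest one, a number 0.70 log units lower from compound 2 to compound 3 (beyond the scatter), removes a six-membered non-aromatic ring of carbon only. Neither exchanges methyl for fluoro, so a smaller upward move in this assay is expected, near the edge of the scatter. The expected step is a number 0.30 log units higher from compound 3 to compound 4 (within the scatter). For compound 4 the estimate is 2.3, with an expected range of 2 to 2.6.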

Compound 4, distribution coefficient: 2.1
Beside the measured number, compound 4's estimate is 0.20 log units above it; the measured number falls inside the stated range.
By their numbers in this assay, from the lowest: compound 1; then compounds 3 and 4 (each within the scatter of the next); then compound 2.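

In this assay, methyl in place of fluoro on this aromatic carbon gives a number 0.10 log units higher from compound 3 to compound 4 (within the scatter), so the 4-fluoro-1H-pyrazol-1-yl and 4-methyl-1H-pyrazol-1-yl compounds cannot be told apart on this read-out. Both methyl and fluoro stand apart from methoxy and from the six-membered non-aromatic ring of carbon only: methyl in place of methoxy gives a number 0.70 log units higher from compound 1 to compound 4 (beyond the scatter), and the reverse side reads a number 0.60 log units lower from compound 2 to compound 4 (beyond the scatter). No measurement on hand gives a reason for these steps. As far as these compounds go, whether an amine, a nitrile or a longer chain on this carbon would stay level with methyl and fluoro remains open.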